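A few compounds are considered here, and "the series" means these few. Any claim that something is new, unique, unknown or untested is made for them only; others in the source may bear on it.

Measured in an assay on CHO cells with metabotropic glutamate receptor 5 (Homo sapiens) as the target; a lower number here means that less compound is needed, a higher number that more compound is needed for the effect:
- compound 1 `O=C(Nc1cc(-c2ccccc2)nn1-c1ccccc1)c1ccsc1` — 1800 nM
- compound 2 `O=C(Nc1cc(-c2ccccc2)nn1-c1ccccc1)c1cnccn1` — 200 nM
- compound 3 `O=C(Nc1cc(-c2ccccc2)nn1-c1ccccc1)c1ccc(F)cc1` — 30 nM

Compound 3 stands lowest of the three; its nearest neighbour is compound 2, and the step of a 6.7-fold lower number from compound 2 to compound 3 (0.82 log units; beyond the scatter) is beyond the scatter, as is a 60-fold lower number from compound 1 to compound 3 (1.78 log units; beyond the scatter) against compound 1. The step of a 9.0-fold lower number from compound 1 to compound 2 (0.95 log units; beyond the scatter) is the third piece of the picture. All three steps replace the whole group on the carbonyl carbon, so none of them measures a single added substituent.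

Compound 4 `O=C(Nc1cc(-c2ccccc2)nn1-c1ccccc1)c1ccc(F)c(F)c1` differs from compound 3 by fluoro in place of hydrogen on an aromatic carbon; read one bond further out, this is 4-fluorophenyl to 3,4-difluorophenyl. Within the data shown here, no measured step bears on it directly. With only whole-group swaps to go by, the expected step of no change at the digits printed from compound 3 to compound 4 (within the scatter) is one within the scatter, no clear direction. Compound 4 is therefore estimated at 30 nM, with a range from 10 nM to 90 nM in this assay.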

Compound 4, half-maximal effective concentration: 10 nM
Compound 4: middle estimate off by 3.0-fold (0.48 log units), on the high side; measured number inside the range.
By their numbers in this assay, from the lowest: compound 4; then compound 3; then compound 2; then compound 1.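

In this assay, among these compounds, fluoro in place of hydrogen gives a 3.0-fold lower number from compound 3 to compound 4 (0.48 log units; beyond the scatter) and so provides the first measured step that adds one substituent instead of replacing the whole group on the carbonyl carbon. This aromatic carbon, ortho to a fluoro group and meta to a large group, therefore accepts a further fluoro, and the number falls beyond the scatter. The 3,4-difluorophenyl group also widens the gap to the other groups on the carbonyl carbon, with a 20-fold lower number from compound 2 to compound 4 (1.30 log units; beyond the scatter) and a 180-fold lower number from compound 1 to compound 4 (2.26 log units; beyond the scatter) as the steps, while no measurement shown accounts for the change.

Still open, from the compounds shown here alone, is whether chloro, methoxy or an amine on the same aromatic carbon would shift the number as fluoro does. A single step also leaves open whether fluoro at this carbon gives a similar shift without the 4-fluoro group.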